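Phenyl to phenethyl on the amine chain of two cores

This account rests on a few compounds, and the source may have more. Where it says the series, first, only, none or still open, it means among the compounds named here.

Compound 1 `CCCn1c(-c2ccco2)nc2c(N)nc(NCc3ccccc3)nc21` gives 138 nM in an assay on CHO cells for displacement of a labelled ligand from adenosine receptor A1 (Homo sapiens); a lower number here means a stronger inhibitor, a higher number a weaker inhibitor. Compound 2 `CCCn1c(-c2ccco2)nc2c(N)nc(NCCCc3ccccc3)nc21` carries the change (phenethyl in place of phenyl on a saturated chain carbon bound to a nitrogen on an aromatic ring); in this assay compound 2 gives 230 nM, a step of a 1.7-fold higher number from compound 1 to compound 2 (0.22 log units; within the scatter). Compound 3 `CCCn1c(-c2ccco2)nc2c(NCc3ccccc3)ncnc21` stands on a different core; the difference between the two cores is not broken down here. In this assay compound 3 gives 546 nM, the highest number of the three. Compound 4 `CCCn1c(-c2ccco2)nc2c(NCCCc3ccccc3)ncnc21` is not yet measured; it differs from compound 3 by phenethyl in place of phenyl on a saturated chain carbon bound to a nitrogen on an aromatic ring, the same change at the same place as between compound 1 and compound 2. Going by the values given here, the expected step is a 1.6-fold higher number from compound 3 to compound 4 (0.19 log units; within the scatter), which rests on the earlier step of a 1.7-fold higher number from compound 1 to compound 2 (0.22 log units; within the scatter) as the only other instance of this change. For compound 4 the estimate in this assay is 850 nM, expected between 400 nM and 2000 nM.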

Compound 4, inhibition constant: 378 nM
The estimate for compound 4 lay 2.2-fold (0.35 log units) above the measured number; the whole stated range lies above it.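

In this assay the change gives a 1.4-fold lower number from compound 3 to compound 4 (0.16 log units; within the scatter), a step too small to read in either direction. Set beside the earlier step, it shows that the two cores cannot be told apart for this change: the same change on two cores in this assay, a 1.7-fold higher number (0.22 log units; within the scatter) from compound 1 to compound 2 and a 1.4-fold lower number (0.16 log units; within the scatter) from compound 3 to compound 4, 2.4-fold (0.38 log units) apart, within the scatter of two such steps. With only two instances, both within the scatter, carrying the change over can be said to leave the number about where it was on these two cores, but this does not show that the same would hold on a further core.

On these data alone, whether a chain longer than 3-phenylpropyl, or an amine or a carboxylic acid in place of the phenyl, would give a step beyond the scatter stays open on both cores.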